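Adding a methyl to the aromatic ring of compound 2

The compounds below may be only part of what the source reports. "The series", "measured", "known", "first", "only" and "open" are said of these compounds alone.

Measured so far:
- compound 1, `N/C(=N\NC(=S)N1CCOCC1)c1ccc(F)cn1`: 4000 nM
- compound 2, `N/C(=N\NC(=S)N1CCOCC1)c1ccccn1`: 4800 nM
- compound 3, `N/C(=N\NC(=S)N1CCCCC1)c1ccccn1`: 6900 nM

These three compounds share a core and were tested in a functional assay on A-431 cells (Homo sapiens) for cytotoxicity, read by MTT assay, with a stated time of 72 h; on this read-out higher numbers stand for weaker inhibition and lower numbers for stronger inhibition. Compound 2 gives 4800 nM, which is the second highest of the three numbers; its neighbours are compound 1 with 4000 nM and compound 3 with 6900 nM, and both lie within the scatter of compound 2.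

The new compound, compound 4 (`Cc1cccc(/C(N)=N/NC(=S)N2CCOCC2)n1`), differs from compound 2 in one place: methyl in place of hydrogen on an aromatic carbon.

Two measured steps are at hand. The step of a 1.2-fold higher number from compound 1 to compound 2 (0.08 log units; within the scatter) changes a substituent on the same aromatic ring, and the step of a 1.4-fold higher number from compound 2 to compound 3 (0.16 log units; within the scatter) changes the ring on the thiocarbonyl carbon; neither left the scatter. For the measured compounds named here, no step shows a methyl entering, so the expectation rests on these small ring changes alone. The expected step is therefore a 1.1-fold lower number from compound 2 to compound 4 (0.03 log units; within the scatter), no change beyond the scatter.

Compound 4 is estimated at 4500 nM, with a range from 2000 nM to 10000 nM.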

Compound 4, half-maximal inhibitory concentration: 4300 nM
Compound 4: middle estimate off by 1.0-fold (0.02 log units), on the high side; low and high end bracket the measured number.
By their numbers in this assay, from the lowest: compounds 1, 4, 2 and 3 (each within the scatter of the next).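

In this assay, methyl in place of hydrogen on this aromatic carbon, next to the ring nitrogen, gives a 1.1-fold lower number from compound 2 to compound 4 (0.05 log units; within the scatter). The earlier compounds shown here showed only hydrogen and fluoro on this ring, so compound 4 adds a first small carbon group and shows that, at this place, it leaves the number within the scatter. No further measurement bears on this result, so the number stands without an explanation.

One methyl says little about how much change this place can accept, so an amine, a carboxylic acid or a longer chain here could give a quite different number. The compounds shown also leave open whether the same methyl on another carbon of the ring would stay within the scatter of compound 2.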